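Replacing 4-methoxyphenyl with furan-3-yl on a shared core

The source may report more compounds than this note shows. Statements on the series, on what has been measured and on what is new or still open speak of the compounds shown alone.

Compound 1 `CC(C)c1ccc(Oc2ccc3nc(/C=C/C(=O)NO)ccc3c2)cc1`: 3280 nM
Compound 2 `COc1ccc(-c2ccc3nc(/C=C/C(=O)NO)ccc3c2)cc1`: 2350 nM

In a functional assay on A549 cells (Homo sapiens) for antiproliferative activity, read by sulforhodamine B assay, with a stated time of 48 h (a higher number here means a weaker inhibitor of growth, a lower number a stronger inhibitor of growth), compound 2, at 2350 nM, stands within the scatter of compound 1, at 3280 nM. Compound 3 `O=C(/C=C/c1ccc2cc(-c3ccoc3)ccc2n1)NO` carries furan-3-yl in place of 4-methoxyphenyl on an aromatic carbon of the shared core (furan-3-yl in place of 4-methoxyphenyl on an aromatic carbon). For the measured compounds named here, no measured step covers this change. Starting from compound 2 at 2350 nM, no step beyond the scatter is expected in this assay, in either direction. For compound 3 the estimated value is 3000 nM, with an expected range of 1000 nM to 9000 nM. The expected change is a 1.3-fold higher number from compound 2 to compound 3 (0.11 log units; within the scatter).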

Compound 3, concentration for 50% growth inhibition: 1920 nM
Beside the measured number, compound 3's estimate is 1.6-fold (0.19 log units) above it; the measured number falls inside the stated range.
By their numbers in this assay, from the lowest: compounds 3, 2 and 1 (each within the scatter of the next).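

In this assay, exchanging 4-methoxyphenyl for furan-3-yl gives a 1.2-fold lower number from compound 2 to compound 3 (0.09 log units; within the scatter), so on this aromatic carbon of the shared core, a five-membered aromatic ring with 1 hetero atom takes the place of a six-membered aromatic ring of carbon only without a step beyond the scatter. No evidence is available that bears on this result. From the compounds shown here alone, whether a morpholine, an amine or a carboxylic acid on this carbon would give a step beyond the scatter remains open.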